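The compounds below may be only part of what the source reports. "The series", "measured", "known", "first", "only" and "open" are said of these compounds alone.

Three close relatives of one scaffold have been measured for how much of each survives in an ADME assay on microsomes from liver (Canis lupus familiaris) for metabolic stability, read by LC-MS, using NADPH, with a stated time of 30 min, tested at 1 uM; a higher number here means that more of the compound is left, a lower number that less of the compound is left. Compound 1 `C=CC(=O)Nc1cc(Nc2ncc(Cl)c(Nc3ccccc3S(=O)(=O)C(C)C)n2)c(OC)cc1N(C)CCN(C)C` gives 17%. Compound 2 `C=CC(=O)Nc1cc(Nc2ncc(Cl)c(Nc3ccccc3S(=O)(=O)N(C)C)n2)c(OC)cc1N(C)CCN(C)C` gives 31%. Compound 3 `C=CC(=O)Nc1cc(Nc2nccc(Nc3ccccc3S(=O)(=O)N(C)C)n2)c(OC)cc1N(C)CCN(C)C` gives 50%, the highest of the three. The change from compound 2 to compound 1 is isopropyl in place of dimethylamino on a sulfonyl sulfur, and with it the result moves by a number 14 percentage points lower from compound 2 to compound 1 (beyond the scatter). The change from compound 2 to compound 3 is hydrogen in place of chloro on an aromatic carbon, and with it the result moves by a number 19 percentage points higher from compound 2 to compound 3 (beyond the scatter).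

Compound 4 `C=CC(=O)Nc1cc(Nc2nccc(Nc3ccccc3S(=O)(=O)C(C)C)n2)c(OC)cc1N(C)CCN(C)C` has not yet been measured. Compared with compound 3, it carries isopropyl in place of dimethylamino on a sulfonyl sulfur. This is the same change that was made from compound 2 to compound 1, seen there as a number 14 percentage points lower from compound 2 to compound 1 (beyond the scatter), and the place where it is made is described in the same words in both cases. The core of compound 3 differs from the core of compound 2 by hydrogen in place of chloro on an aromatic carbon, so the change is now made on the core that gave the higher number.

On this basis compound 4 is expected to fall short of compound 3 by about a number 14 percentage points lower from compound 3 to compound 4 (beyond the scatter), resting on compound 2 to compound 1 showing a number 14 percentage points lower from compound 2 to compound 1 (beyond the scatter). Compound 4 is therefore estimated at 36%, with a plausible range from 24% to 48%. The next measurement will show whether the drop repeats on this core.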

Compound 4, percent of the compound remaining: 48%
Beside the measured number, compound 4's estimate is 12 percentage points below it; the measured number falls inside the stated range.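

In this assay, isopropyl in place of dimethylamino on a sulfonyl sulfur now gives a number 2 percentage points lower from compound 3 to compound 4 (within the scatter), a step too small to count as a real change on this core, yet it cannot be told apart from the earlier step on the chlorinated core: the same change on two cores in this assay, a number 14 percentage points lower (beyond the scatter) from compound 2 to compound 1 and a number 2 percentage points lower (within the scatter) from compound 3 to compound 4, 12 percentage points apart, within the scatter of two such steps. The other change, hydrogen in place of chloro on an aromatic carbon, gives a number 31 percentage points higher from compound 1 to compound 4 (beyond the scatter), and it too agrees with its earlier counterpart: the same change on two cores in this assay, a number 19 percentage points higher (beyond the scatter) from compound 2 to compound 3 and a number 31 percentage points higher (beyond the scatter) from compound 1 to compound 4, 12 percentage points apart, within the scatter of two such steps. Among the compounds shown here, these four compounds therefore give no firm sign that either change behaves differently from one core to the other, but with only two steps per change and gaps this wide, they do not prove that either change has the same size on both cores, and they offer no explanation for any step.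

The compounds shown carry only dimethylamino or isopropyl on the sulfonyl sulfur, so it remains open how a morpholine, a methyl or a cyclopropyl group there would fare in this assay. They also carry only hydrogen or chloro on the aromatic carbon, which leaves open whether a fluorine, a methyl or a nitrile at that place would follow the same trend.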